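The compounds below may be only part of what the source reports. "The series", "measured", "known", "first", "only" and "open" are said of these compounds alone.

Two amides sharing one core have been measured. In a functional assay on SiHa cells (Homo sapiens) for cytotoxicity, read by MTT assay, with a stated time of 48 h (a lower number here means a stronger inhibitor, a higher number a weaker inhibitor), compound 1 `CCCCCCCCNC(=O)[C@@H](NC(=O)c1cc2ccccc2o1)[C@@H](C)O` gives 66500 nM, and compound 2 `CCCCCCCCCCCCCCNC(=O)[C@@H](NC(=O)c1ccco1)[C@@H](C)O` gives 127000 nM. Compound 2 thus sits at the higher of the two numbers, though its distance from compound 1 lies within the scatter. Compound 3 `CCCCCCCCCCCCCCNC(=O)[C@@H](NC(=O)c1cc2ccccc2o1)[C@@H](C)O` differs from compound 2 by 1-benzofuran-2-yl in place of furan-2-yl on a carbonyl carbon. For the measured compounds named here, no measured pair isolates this change, and both known values are weak and close together, so no step beyond the scatter is expected. The estimated step is a 1.5-fold lower number from compound 2 to compound 3 (0.17 log units; within the scatter) in this assay. Compound 3 is expected at 85000 nM, between 30000 nM and 250000 nM.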

Compound 3, half-maximal inhibitory concentration: 14200 nM
Estimate against measurement, compound 3: 6.0-fold (0.78 log units) above, and the stated range ends above it.
By their numbers in this assay, from the lowest: compound 3; then compounds 1 and 2 (each within the scatter of the next).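

In this assay, changing furan-2-yl to 1-benzofuran-2-yl on a carbonyl carbon now has a measured size, with an 8.9-fold lower number from compound 2 to compound 3 (0.95 log units; beyond the scatter). Hexyl in place of hydrogen on a saturated chain carbon, eight bonds along the chain from an amide-type nitrogen, also matters, with a 4.7-fold lower number from compound 1 to compound 3 (0.67 log units; beyond the scatter). Nothing measured here explains either step. Going by these compounds, whether a longer chain than that of compound 3 would lower the number again remains open. So does the effect of placing a carboxylic acid or an amine on that chain.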